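Methyl in Place of Chloro: Expectation for Compound 4

The source may report more compounds than this note shows. Statements on the series, on what has been measured and on what is new or still open speak of the compounds shown alone.

Three compounds have been measured in a functional assay on MCF7 cells (Homo sapiens) for inhibition; on this read-out higher numbers stand for weaker inhibition and lower numbers for stronger inhibition:

Compound 1 `CCn1c(=O)/c(=C2\Sc3ccc(C)cc3N2C)s/c1=C\c1ccncc1Nc1ccccc1Cl` gives 650 nM.
Compound 2 `CCn1c(=O)/c(=C2\Sc3ccccc3N2C)s/c1=C\c1ccncc1Nc1ccccc1Cl` gives 750 nM.
Compound 3 `CCn1c(=O)/c(=C2\Sc3ccc(OC)cc3N2C)s/c1=C\c1ccncc1Nc1ccccc1Cl` gives 710 nM.

Compound 1 shows the lowest of the three numbers, yet its steps to the others, a 1.2-fold higher number from compound 1 to compound 2 (0.06 log units; within the scatter) and a 1.1-fold higher number from compound 1 to compound 3 (0.04 log units; within the scatter), both lie within the scatter, so the three cannot be told apart. Compound 4 `CCn1c(=O)/c(=C2\Sc3ccc(C)cc3N2C)s/c1=C\c1ccncc1Nc1ccccc1C` differs from compound 1 by methyl in place of chloro on an aromatic carbon. Among the measured compounds shown here, no measured step touches that place; the known steps all concern a different aromatic carbon, and each stayed within the scatter. With nothing pointing in either direction, compound 4 is expected to sit close to compound 1, an estimated step of a 1.1-fold higher number from compound 1 to compound 4 (0.03 log units; within the scatter) in this assay. The estimate for compound 4 is 700 nM, between 300 nM and 1600 nM.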

Compound 4, half-maximal inhibitory concentration: 400 nM
Compound 4: middle estimate off by 1.8-fold (0.24 log units), on the high side; measured number inside the range.
By their numbers in this assay, from the lowest: compounds 4, 1, 3 and 2 (each within the scatter of the next).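

Among the compounds shown here, this is the first look at the chloro position on the 2-chlorophenyl group, since the earlier steps all concerned a different aromatic carbon. In this assay, the change to 2-methylphenyl gives a 1.6-fold lower number from compound 1 to compound 4 (0.21 log units; within the scatter), so chloro and methyl cannot be told apart at this place. No available evidence explains this result.

Only these two groups have been seen at this position, so one pair cannot show how much it tolerates. Going by these compounds, whether an amine or a carboxylic acid in place of the chloro would shift the number beyond the scatter remains open.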